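The compounds below may be only part of what the source reports. "The series", "measured", "known", "first", "only" and "open" are said of these compounds alone.

Compound 2 `COc1cc(C)cc(Sc2cccc(N)c2C#N)c1` and compound 1 `Cc1cc(C)cc(Sc2cccc(N)c2C#N)c1` share one core and differ in a single change, (methyl in place of methoxy on an aromatic carbon). In a functional assay on MT4 cells (Homo sapiens) for cytotoxicity (on this read-out higher numbers stand for weaker inhibition and lower numbers for stronger inhibition), compound 2 gives 10000 nM. For compound 1 this assay reports only a limit, > 2000 nM. The step that the limit leaves unreadable from compound 2 to compound 1 therefore has no readable size, because the limit of > 2000 nM in this assay, at which 1 of the 3 values shown sits, is all that compound 1 yields there.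

Compound 3 `COc1cccc([S+]([O-])c2cccc(N)c2C#N)c1` stands on a different core; the difference between the two cores is not broken down here. For compound 3 this assay again reports only a limit, > 80000 nM. Compound 4 `Cc1cccc([S+]([O-])c2cccc(N)c2C#N)c1` has not yet been measured in this assay. It differs from compound 3 by methyl in place of methoxy on an aromatic carbon, the same kind of change as from compound 2 to compound 1; the earlier place was in addition meta to a methyl group (1 heavy atom), which is not so in compound 3.

Since the earlier step is unreadable and compound 3 sits at a limit, compound 4 is expected to sit near a limit as well. The expected step is a step that the limit leaves unreadable from compound 3 to compound 4. Compound 4 is estimated at 100000 nM, most likely between 30000 nM and 300000 nM.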

Compound 4, half-maximal inhibitory concentration: > 200000 nM
Compound 4: only a limit was reported (the forecaster's own chance of this, stated with the estimate: 70%); at least 2.0-fold (0.30 log units) between middle value and limit.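

Compound 3 and compound 4 are both reported in this assay only as limits, and the step between them cannot be read. The compounds shown leave open how far methyl in place of methoxy moves this read-out on either core, as the step between compound 2 and compound 1 cannot be read either.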